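The compounds below may be only part of what the source reports. "The series", "measured", "known", "first", "only" and "open" are said of these compounds alone.

Within the data shown here, compound 3, whose structure is `COc1ccc(NC(=O)CN2CCN(c3nnc(Cc4ccccc4)c4ccccc34)CC2)cc1OC`, gives in a functional assay on MDA-MB-231 cells (Homo sapiens) for cytotoxicity, read by MTT assay, with a stated time of 72 h (a lower number here means a stronger inhibitor, a higher number a weaker inhibitor), a reading of 32200 nM, the highest of the three numbers measured so far. Compound 1, with the structure `O=C(CN1CCN(c2nnc(Cc3ccncc3)c3ccccc23)CC1)Nc1ccc(F)c(F)c1`, gives 0.84 nM, and compound 2, with the structure `O=C(CN1CCN(c2nnc(Cc3ccncc3)c3ccccc23)CC1)Nc1cccc(F)c1`, gives 4.4 nM. Among the measured compounds shown here, the only single-point step measured is a 5.2-fold higher number from compound 1 to compound 2 (0.72 log units; beyond the scatter), which concerns a fluoro on the anilide ring and says nothing directly about the change now in view. Compound 4, with the structure `O=C(CN1CCN(c2nnc(Cc3ccccc3)c3ccccc23)CC1)Nc1ccc(F)c(Cl)c1`, differs from compound 3 by 3-chloro-4-fluorophenyl in place of 3,4-dimethoxyphenyl on an amide-type nitrogen. For the measured compounds named here, no measured pair isolates this exchange, and compound 3 also differs from compounds 1 and 2 elsewhere in the molecule, so the gap between them cannot be assigned to the anilide alone. Still, both compounds carrying a halogenated anilide sit far below compound 3. He therefore expects a large step downward for compound 4, a 320-fold lower number from compound 3 to compound 4 (2.51 log units; beyond the scatter), while leaving a wide range because the support is indirect. His estimate for compound 4 in this assay is 100 nM, between 2 nM and 5000 nM.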

Compound 4, half-maximal inhibitory concentration: 7360 nM
Estimate against measurement, compound 4: 74-fold (1.87 log units) below; the whole stated range lies below it.
By their numbers in this assay, from the lowest: compound 1; then compound 2; then compound 4; then compound 3.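

Among these compounds, the pair of compound 3 and compound 4 is the first to isolate the group on an amide-type nitrogen: with the rest of the molecule unchanged, 3-chloro-4-fluorophenyl in place of 3,4-dimethoxyphenyl gives a 4.4-fold lower number from compound 3 to compound 4 (0.64 log units; beyond the scatter) in this assay. The step lies beyond the scatter but is modest, and compound 4 still reads 7360 nM. Nothing available explains the size of this step.

Compound 1 and compound 2 each differ from compound 4 in more than one place, so no pair shown isolates the other difference in their structures. As far as these compounds go, how this position would respond to other groups, such as a phenyl carrying an amine or a carboxylic acid, also remains open.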